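This account rests on a few compounds, and the source may have more. Where it says the series, first, only, none or still open, it means among the compounds named here.

Working notes on the series. Two compounds carry numbers in a functional assay (Homo sapiens), tested at 1 uM (on this read-out higher numbers stand for a weaker effect at the one concentration tested and lower numbers for a stronger effect), so far. Compound 1, `O=C(/C=C/c1ccccc1)N1CCc2c(Cl)c(O)c(O)c(Cl)c2C1`, gives 83% in this assay. Compound 2, `O=C(CCCc1ccc([N+](=O)[O-])cn1)N1CCc2c(Cl)c(O)c(O)c(Cl)c2C1`, gives 74% in this assay; this number and that of compound 1 lie within the scatter of each other, so neither can be placed ahead of the other. Among the compounds with values here, the two differ in more than one place, so no single step between them is counted.

Compound 3, `COc1ccc(CCCC(=O)N2CCc3c(Cl)c(O)c(O)c(Cl)c3C2)nc1`, is next to be measured in this assay. Against compound 2 it shows (methoxy in place of nitro on an aromatic carbon). Within the data shown here, with only two measured compounds, both in the same band, there is no counted step in this assay to guide the size of this change. The expected step in this assay is a number 1 percentage points higher from compound 2 to compound 3 (within the scatter), within the scatter. Compound 3 is accordingly estimated at 75% in this assay, with a range from 55% to 92%.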

Compound 3, a percentage reported as activity, at one concentration (the size of the read-out at that concentration, not a potency): 96%
The estimate for compound 3 lay 21 percentage points below the measured number, and the stated range ends below it.
By their numbers in this assay, from the lowest: compounds 2 and 1 (each within the scatter of the next); then compound 3.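

In this assay, the group on this aromatic carbon, two atoms from the ring nitrogen and para to a large group, now proves able to move the read-out: methoxy in place of nitro gives a number 22 percentage points higher from compound 2 to compound 3 (beyond the scatter), a change towards a weaker effect at the one concentration tested. Within the data shown here, this is the first counted step, and with the rest of the molecule held the same, it ties the difference to the change from 5-nitropyridin-2-yl to 5-methoxypyridin-2-yl. No measured evidence bears on the origin of this difference.

This single pair does not separate the departure of nitro from the arrival of methoxy. Open also is where an amine, a nitrile or a plain hydrogen on the same carbon would fall relative to these two groups.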